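A few compounds are considered here, and "the series" means these few. Any claim that something is new, unique, unknown or untested is made for them only; others in the source may bear on it.

Of the compounds shown here, two sharing one core have been measured so far in a functional assay on MCF7 cells (Homo sapiens) for cytotoxicity, read by MTT assay, with a stated time of 72 h; on this read-out lower numbers stand for stronger inhibition and higher numbers for weaker inhibition. Compound 1 (`CCCCCCCCCCCCCCCCOP(=O)([O-])OCCC[N+](C)(C)Cc1ccccc1`) gives 57600 nM there. Within the data shown here, compound 2 (`CCCCCCCCCCCCCCCCOP(=O)([O-])OCCC[N+](C)(C)C`) gives 45200 nM in the same test, and this value lies within the scatter of the one for compound 1, so the pair sets no order. The open question is compound 3 (`CCCCCCCCCCCCCCCCOP(=O)([O-])OCCC[n+]1ccccc1`), which departs from compound 2 by a group of 6 heavy atoms (5 carbon, 1 nitrogen; one six-membered aromatic ring with 1 hetero atom) in place of a group of 4 heavy atoms (3 carbon, 1 nitrogen; no ring), on a saturated chain carbon, three bonds along the chain from an oxygen on a saturated chain carbon, three bonds along the chain from an oxygen. Both groups carry a net charge of +1, but only the entering one holds a six-membered aromatic ring with 1 hetero atom. Among the measured compounds shown here, the only measured step that bears on this is a 1.3-fold lower number from compound 1 to compound 2 (0.11 log units; within the scatter), which is small and also changes a group on the charged end of the molecule. It does not cover this new ring, so the evidence is thin. No change beyond the scatter is expected, and the estimated move is a 1.1-fold lower number from compound 2 to compound 3 (0.05 log units; within the scatter) on this evidence. For compound 3 the expected value is 40000 nM, with an estimated range from 18000 nM to 90000 nM in this assay once it is run.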

Compound 3, half-maximal inhibitory concentration: 50400 nM
Compound 3: middle estimate off by 1.3-fold (0.10 log units), on the low side; measured number inside the range.
By their numbers in this assay, from the lowest: compounds 2, 3 and 1 (each within the scatter of the next).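

In this assay, putting the group with the six-membered aromatic ring with 1 hetero atom at this place, on a saturated chain carbon, three bonds along the chain from an oxygen, gives a 1.1-fold higher number from compound 2 to compound 3 (0.05 log units; within the scatter). Set against the group of 10 heavy atoms, the same ring gives a 1.1-fold lower number from compound 1 to compound 3 (0.06 log units; within the scatter), so the group with no ring, the one with a ring of carbon only and the one with a ring with 1 hetero atom all lie within the scatter of one another and set no order at this place, which the earlier pair alone could not show for a ring with a hetero atom. Nothing on hand accounts for this result.

From the compounds shown here alone, all three groups carry a net charge of +1 and all three compounds share the same long chain, so it stays open whether a group with no such charge at this place, such as a hydroxyl group or a carboxylic acid, would separate from them in this assay. Going by these compounds, it also stays open whether a methyl group on the new ring, or a shorter chain on the other end of the core, would move the number beyond the scatter.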